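This account rests on a few compounds, and the source may have more. Where it says the series, first, only, none or still open, it means among the compounds named here.

In an ADME assay on Raji cells (Homo sapiens) for cytotoxicity, read by luminescence, with a stated time of 72 h (a lower number here means that less compound is needed, a higher number that more compound is needed for the effect), compound 3 (`CCCCOc1cccc(-c2[nH]c3cc(OC)ccc3c(=O)c2C(=O)OCC)c1`) gives > 21500 nM as a limit and not a number. Compound 1 (`CCOC(=O)c1c(-c2cccc(-c3ccccc3)c2)[nH]c2cc(OC)ccc2c1=O`) gives > 21500 nM as a limit too. Compound 2 (`CCOC(=O)c1c(-c2cccc(OC)c2)[nH]c2cc(OC)ccc2c1=O`) gives > 21500 nM as a limit too. All three thus share one reading (the limit of > 21500 nM in this assay, at which 3 of the 3 values shown sit).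

Compound 4 (`CCOC(=O)c1c(-c2cccc(OCC(C)C)c2)[nH]c2cc(OC)ccc2c1=O`) differs from compound 3 (isopropyl in place of propyl on a saturated chain carbon bound to an oxygen on an aromatic ring) with isopropyl in place of propyl on a saturated chain carbon bound to an oxygen on an aromatic ring, which reads as butoxy to isobutoxy. The nearest measured change, with propyl in place of hydrogen at that same place, is a step that the two limits leave unreadable from compound 2 to compound 3 and so gives no size to carry over. Two changes of phenyl on an aromatic carbon bear on it less closely (a step that the two limits leave unreadable from compound 1 to compound 2) and (a step that the two limits leave unreadable from compound 1 to compound 3) and are equally without a size.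

No step beyond the scatter is therefore expected in this assay and no direction is expected either. The estimated result is a step that the limit leaves unreadable from compound 3 to compound 4 as an expectation only. A further limit is the likeliest report. The estimate for compound 4 is 25000 nM with an expected range from 12000 nM to 50000 nM as its span.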

Compound 4, half-maximal effective concentration: > 21500 nM
Compound 4: a limit, no number; the forecaster's own chance of this, stated with the estimate: 85%; the middle value does not contradict the limit.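

Compound 4 gives > 21500 nM in this assay, a limit and not a number. No step from compound 1, compound 2 or compound 3 to compound 4 can be read: the limit of > 21500 nM in this assay, at which 4 of the 4 values shown sit.

The compounds shown leave open how far each of the four lies from that limit, and whether butoxy to isobutoxy changes the reading at all.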